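Dichloroacetamides at the cytotoxicity limit: compound 3 to 4

The compounds below may be only part of what the source reports. "The series", "measured", "known", "first", "only" and "open" are said of these compounds alone.

Measured in a functional assay on KB 3-1 cells (Homo sapiens) for cytotoxicity, read by MTT assay, with a stated time of 68 h; a higher number here means a weaker inhibitor, a lower number a stronger inhibitor:
- Compound 1 `O=C(Nc1cccc(-c2cccc(F)c2)c1)C(Cl)Cl`: > 50000 nM (a limit)
- Compound 2 `O=C(Nc1cccc(-c2ccccn2)c1)C(Cl)Cl`: > 50000 nM (a limit)
- Compound 3 `O=C(Nc1cccc(-c2cccc(NC(=O)C(Cl)Cl)c2)c1)C(Cl)Cl`: > 50000 nM (a limit)

Compound 3 stands at a limit, > 50000 nM, so its place in the series cannot be ranked. The evidence so far is uniform: the limit of > 50000 nM in this assay, at which 3 of the 3 values shown sit. Compound 4 `O=C(Nc1cccc(-c2ccccc2)c1)C(Cl)Cl` has hydrogen in place of ((dichloromethyl)carbonyl)amino on an aromatic carbon. Among the measured compounds shown here, the one measured step bearing on this change is a step that the two limits leave unreadable from compound 1 to compound 3, which gives no size to carry over. No step beyond the scatter is therefore expected in this assay, and a reading at the same limit is the likeliest outcome. The expected step is a number no higher from compound 3 to compound 4 (the limit leaves the size open). For compound 4 the estimated value is 50000 nM, with an expected range of 20000 nM to 100000 nM.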

Compound 4, half-maximal inhibitory concentration: 46800 nM
The estimate for compound 4 lay 1.1-fold (0.03 log units) above the measured number, within the range that was stated.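

In this assay, among the compounds shown here, compound 4 gives the first number rather than a limit, with hydrogen in place of ((dichloromethyl)carbonyl)amino (an at least 1.0-fold lower number from compound 3 to compound 4 (0.02 log units; that floor lies within the scatter)). Phenyl in place of pyridin-2-yl (an at least 1.0-fold lower number from compound 2 to compound 4 (0.02 log units; that floor lies within the scatter)) and hydrogen in place of fluoro (an at least 1.0-fold lower number from compound 1 to compound 4 (0.02 log units; that floor lies within the scatter)) read the same way. Each floor lies within the scatter, so none of these changes is shown to shift the result: (the limit of > 50000 nM in this assay, at which 3 of the 4 values shown sit).

On these data alone, whether an amine, a carboxylic acid or a longer chain at this position would bring the number clear of the limit remains open.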